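Removing a Methoxy Group from a Fused Ring

This account rests on a few compounds, and the source may have more. Where it says the series, first, only, none or still open, it means among the compounds named here.

Of the compounds shown here, three sharing one core have been measured in a functional assay on Hs-578T cells (Homo sapiens) for inhibition, read by sulforhodamine B assay, with a stated time of 48 h; on this read-out lower numbers stand for stronger inhibition of growth and higher numbers for weaker inhibition of growth. Compound 1 `COc1ccc(-c2[nH]c3ccccc3c2/C=C(\C#N)S(=O)(=O)c2ccccc2)cc1` gives 682 nM. Compound 2 `O=C(/C(=C\c1c(-c2ccccc2)[nH]c2ccccc12)S(=O)(=O)c1ccccc1)c1ccccc1` gives 39500 nM. Compound 3 `COc1ccc2[nH]c(-c3ccccc3)c(/C=C(\C#N)S(=O)(=O)c3ccccc3)c2c1` gives 7600 nM. On these numbers compound 3 stands second highest of the three: its nearest neighbour is compound 2, whose number is higher by a gap beyond the usual scatter, and furthest from it is compound 1, whose number is lower by a gap also beyond the scatter.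

Compound 4 `N#C/C(=C\c1c(-c2ccccc2)[nH]c2ccccc12)S(=O)(=O)c1ccccc1` has not yet been measured in this assay. It differs from compound 3 in one place: hydrogen in place of methoxy on an aromatic carbon of a six-membered aromatic ring of carbon only, part of a fused system of two rings.

Among the compounds with values here, no measured pair differs in exactly this way, so the size of the step is uncertain. Compounds 1 and 3 carry the same methoxy group on different rings and their numbers lie far apart, but neither tells directly what losing the group does. A moderate move toward lower numbers is expected, placing compound 4 between compound 3 and compound 1. The step this estimate means is a 2.5-fold lower number from compound 3 to compound 4 (0.40 log units; beyond the scatter), an expectation rather than a measurement. For compound 4 the estimate in this assay is 3000 nM, with a range from 800 nM to 12000 nM.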

Compound 4, concentration for 50% growth inhibition: 23600 nM
For compound 4 the middle estimate is 7.9-fold (0.90 log units) below the measured one, and the stated range ends below it.
By their numbers in this assay, from the lowest: compound 1; then compound 3; then compounds 4 and 2 (each within the scatter of the next).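

In this assay, taking the methoxy group off the fused ring gives a 3.1-fold higher number from compound 3 to compound 4 (0.49 log units; beyond the scatter), so at this position the group goes with stronger inhibition of growth. Compound 4 also serves as the methoxy-free partner of compound 1, where the same group sits on a different ring, and that change gives a 35-fold higher number from compound 1 to compound 4 (1.54 log units; beyond the scatter), so the methoxy group goes with stronger inhibition at both places, and by much more in compound 1. Among the two compounds without a methoxy group, putting cyano in place of benzoyl gives a 1.7-fold lower number from compound 2 to compound 4 (0.22 log units; within the scatter), a step within the usual scatter, so these two groups cannot be told apart on this core.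

On these data alone, it remains open whether a hydroxyl group, a fluorine atom or a longer chain such as ethoxy on the fused ring would do what methoxy does, and whether benzoyl and cyano would still fall within the scatter of each other on a core carrying methoxy. Nothing available gives a reason for these steps or for the difference between the two rings.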